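From Furan-3-yl to Thiophen-2-yl: an Untested Swap

This account rests on a few compounds, and the source may have more. Where it says the series, first, only, none or still open, it means among the compounds named here.

Measured compounds:
compound 1 `COC(=O)C1=C(C)NC(=S)NC1c1ccoc1` — 25% in an assay on membranes from CHO cells for displacement of a labelled ligand from adenosine receptor A1 (Homo sapiens), read by scintillation counting, with a stated time of 60 min, tested at 1 uM; a higher number here means more inhibition at the concentration tested (going by the name of the read-out), a lower number less inhibition
compound 2 `CC1=C(C(=O)OC(C)(C)C)C(c2ccoc2)NC(=S)N1` — 18% in this assay
compound 3 `CC1=C(C(=O)OCc2ccccc2)C(c2ccoc2)NC(=S)N1` — 25% in this assay

Compound 1 sits level with compound 3: no change at the digits printed from compound 1 to compound 3 (within the scatter). Against compound 2 the gap is a number 7 percentage points lower from compound 1 to compound 2 (within the scatter), and a number 7 percentage points higher from compound 2 to compound 3 (within the scatter) closes the triangle. Among the compounds with values here, all three numbers thus lie within the scatter of one another, and no compound can be ranked above the others.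

Compound 4 `COC(=O)C1=C(C)NC(=S)NC1c1cccs1` differs from compound 1 in one place: thiophen-2-yl in place of furan-3-yl on a saturated ring carbon. Within the data shown here, every measured step so far changes the group on the oxygen next to the carbonyl, not the five-membered aromatic ring on the saturated ring carbon, so no measured step bears directly on this swap. What the three steps do show is that altering one substituent on this shared core left this assay unmoved beyond the scatter. The step from compound 1 to compound 4 is therefore expected to be no change at the digits printed from compound 1 to compound 4 (within the scatter), with no direction favoured. Compound 4 is estimated at 25%, expected between 10% and 42%.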

Compound 4, a percentage reported as inhibition, at one concentration (the size of the read-out at that concentration, not a potency): 1%
Estimate against measurement, compound 4: 24 percentage points above; measured number below the stated range.
By their numbers in this assay, from the lowest: compound 4; then compounds 2, 1 and 3 (each within the scatter of the next).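

The five-membered aromatic ring on the saturated ring carbon matters in this assay: putting thiophen-2-yl in place of furan-3-yl gives a number 24 percentage points lower from compound 1 to compound 4 (beyond the scatter). This is the only step shown that lies beyond the scatter, so this position responds to a change where the group on the oxygen next to the carbonyl did not, even though the two rings match in heavy-atom count and in hydrogen-bond donors and acceptors. No measurement available here accounts for this difference between the two rings.

The swap changes both the hetero atom, from oxygen to sulfur, and the ring's point of attachment, so the compounds shown cannot say which of the two counts; furan-2-yl and thiophen-3-yl on the same carbon would separate them. From the compounds shown here alone, whether the same step appears with tert-butyl or benzyl on the oxygen next to the carbonyl also remains open.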